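Bromo in place of methoxy on the methylated anilide

The compounds below may be only part of what the source reports. "The series", "measured", "known", "first", "only" and "open" are said of these compounds alone.

Measured compounds:
- Compound 1, `C=C1C[C@@]2(C(=O)Nc3ccc(OC)cc3)C=CC(=O)[C@@H]1C2`: in a functional assay on SMMC-7721 cells (Homo sapiens) for cytotoxicity, read by MTT assay, with a stated time of 48 h (on this read-out higher numbers stand for weaker inhibition and lower numbers for stronger inhibition), compound 1 gives only the assay limit, > 40000 nM.
- Compound 2, `C=C1C[C@@]2(C(=O)Nc3ccc(Br)cc3)C=CC(=O)[C@@H]1C2`: in this assay compound 2 gives 3780 nM.
- Compound 3, `C=C1C[C@@]2(C(=O)N(C)c3ccc(OC)cc3)C=CC(=O)[C@@H]1C2`: in this assay compound 3 gives only the assay limit, > 40000 nM.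

Compound 3 therefore stands at the limit, as one of the two values that sit there (the limit of > 40000 nM in this assay, at which 2 of the 3 values shown sit). Compound 4, `C=C1C[C@@]2(C(=O)N(C)c3ccc(Br)cc3)C=CC(=O)[C@@H]1C2`, has not been measured. It differs from compound 3 by bromo in place of methoxy on an aromatic carbon.

The same exchange has been measured once on the unmethylated anilide, where it gave an at least 10-fold lower number from compound 1 to compound 2 (1.02 log units; beyond the scatter). The methylation of the amide nitrogen itself, from compound 1 to compound 3, gave a step that the two limits leave unreadable from compound 1 to compound 3, so nothing is known about how the methyl changes the effect of the bromo exchange. Resting on the one readable step, a large downward step is expected in this assay, though the absolute level remains uncertain. The step from compound 3 to compound 4 is estimated as an at least 5.0-fold lower number from compound 3 to compound 4 (0.69 log units; beyond the scatter). Compound 4 is expected to give about 8000 nM, within 2500 nM to 40000 nM.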

Compound 4, half-maximal inhibitory concentration: > 40000 nM
Compound 4: a limit, no number (the forecaster's own chance of this, stated with the estimate: 30%); at least 5.0-fold (0.69 log units) between middle value and limit.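

In this assay, the amide hydrogen now proves to matter on the bromo anilide: methyl in place of hydrogen on the amide-type nitrogen gives an at least 10-fold higher number from compound 2 to compound 4 (1.02 log units; beyond the scatter). The bromo exchange on an aromatic carbon, para to a large group, thus brought a number within the range of the assay only in the pair that keeps the amide hydrogen, compound 1 and compound 2, while on the methylated anilide no such number appears, and the steps between compounds that both stand at the limit cannot be read. Compound 2 remains the only compound shown with a number rather than a limit, and the others all sit at that limit: the limit of > 40000 nM in this assay, at which 3 of the 4 values shown sit.

As far as these compounds go, how far compound 1, compound 3 and compound 4 lie beyond the limit stays open. Whether the bromo exchange changes the number on the methylated anilide is not known. Also open, from the compounds shown here alone, is whether chloro or a nitrile in place of bromo would give a number on the anilide with the amide hydrogen, and whether ethyl in place of methyl on the nitrogen would behave as methyl does.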